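The source may report more compounds than this note shows. Statements on the series, on what has been measured and on what is new or still open speak of the compounds shown alone.

Working notes on the isopropyl-purine series. Among the compounds with values here, compound 1 `CC(C)n1cnc2c(NC(=N)N)nc(N)nc21` is the only member with a number in a functional assay on MCF7 cells (Homo sapiens) for inhibition, read by fluorescence, with a stated time of 72 h; a higher number here means a weaker inhibitor, a lower number a stronger inhibitor; there compound 1 gives 97200 nM. Compound 2 `CC(C)n1cnc2c(N)nc(N)nc21` carries a hydrogen atom in place of the guanidine-like group on the ring nitrogen. In this assay compound 2 returns only a limit, > 100000 nM, not a number. Within the data shown here, the single measured step, an at least 1.0-fold higher number from compound 1 to compound 2 (0.01 log units; that floor lies within the scatter), therefore rests on that limit of > 100000 nM in this assay, at which 1 of the 2 values shown sits, and sets only a floor on the change.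

Compound 3 `CC(C)n1cnc2c(NC(=N)N)nc(NCCCCCCO)nc21` is not yet measured. It keeps the whole of compound 1 and differs by 6-hydroxyhexyl in place of hydrogen on a nitrogen on an aromatic ring. Among the measured compounds shown here, no measured step touches this nitrogen; the one step in hand alters a different substituent, so it gives no direct guide to the size or direction of the change in this assay. With nothing beyond compound 1 to lean on, the expectation is a half-maximal inhibitory concentration of the same order as compound 1, with wide uncertainty.

Compound 3 is estimated at 70000 nM in this assay, within 15000 nM to 200000 nM. The implied step, a 1.4-fold lower number from compound 1 to compound 3 (0.14 log units; within the scatter), is expected to stay within the usual scatter.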

Compound 3, half-maximal inhibitory concentration: 5200 nM
For compound 3 the middle estimate is 13-fold (1.13 log units) above the measured one, and the stated range ends above it.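

In this assay, the nitrogen on an aromatic ring that carries hydrogen in compound 1 responds strongly to substitution: 6-hydroxyhexyl in place of hydrogen gives a 19-fold lower number from compound 1 to compound 3 (1.27 log units; beyond the scatter) and so moves the series from near the top of the measured range into a clearly stronger region. Within the data shown here, this is the first measured change at this nitrogen and the first step read between two numbers, with a size that stands beyond the scatter. The earlier step concerns a different place and offers only a floor, an at least 1.0-fold higher number from compound 1 to compound 2 (0.01 log units; that floor lies within the scatter) and rests on a limit rather than a number: the limit of > 100000 nM in this assay, at which 1 of the 3 values shown sits.

The compounds shown leave open whether the change in this assay follows from the chain itself or from its terminal hydroxyl, and a plain hexyl chain, a shorter or longer chain, or a terminal amine or carboxylic acid in place of the hydroxyl would separate these readings. They also leave open whether 6-hydroxyhexyl has a comparable effect when the guanidine-like group is replaced by hydrogen on the other ring nitrogen.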